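Swapping the outer ring of compound 2 for a dimethyl-oxazole

The source may hold more compounds than are shown below. What is called first, only, known or untested is meant among the compounds shown, and "the series" means these compounds.

Compound 2 `Cc1ccccc1-c1cccc(CNc2ccc(OCC(=O)O)c(F)c2)c1` stands lowest among the three measured compounds in a functional assay on CHO cells for agonist activity at Free fatty acid receptor 1 (Homo sapiens), read by FLIPR and calcium flux (on this read-out lower numbers stand for an effect already at smaller amounts and higher numbers for an effect only at larger amounts of compound), with compound 2 giving 4.8 nM. Compound 1 `O=C(O)COc1ccc(NCc2cccc(-c3ccccc3)c2)cc1F` lacks the methyl on the outer ring and gives 58.5 nM; the step of a 12-fold lower number from compound 1 to compound 2 (1.09 log units; beyond the scatter) is large. Compound 3 `CCCOc1ccc(-c2cccc(CNc3ccc(OCC(=O)O)c(F)c3)c2)c(C)c1` carries an added propoxy on that ring and gives 41.3 nM; the step of an 8.6-fold higher number from compound 2 to compound 3 (0.93 log units; beyond the scatter) is modest.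

Compound 4 `Cc1noc(C)c1-c1cccc(CNc2ccc(OCC(=O)O)c(F)c2)c1` is not yet measured. Relative to compound 2 the change is 3,5-dimethyl-1,2-oxazol-4-yl in place of 2-methylphenyl on an aromatic carbon. Neither measured step covers exactly this kind of swap; both only show that changes to the outer ring move the read-out well beyond the scatter, in either direction. The new group keeps a methyl on each side of the attachment point and has the same number of heavy atoms as the 2-methylphenyl it replaces, but it is a five-membered ring with two hetero atoms instead of a six-membered ring of carbon only.

For compound 4 a step of a 3.1-fold higher number from compound 2 to compound 4 (0.49 log units; beyond the scatter) is therefore expected, toward a higher number but not as far as either measured step. The estimate for compound 4 in this assay is 15 nM, with a range from 3 nM to 80 nM.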

Compound 4, half-maximal effective concentration: 225 nM
The estimate for compound 4 lay 15-fold (1.18 log units) below the measured number; measured number outside the range, above it.
By their numbers in this assay, from the lowest: compound 2; then compounds 3 and 1 (each within the scatter of the next); then compound 4.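

The swap keeps the number of heavy atoms and carries no net charge, yet in this assay replacing 2-methylphenyl with 3,5-dimethyl-1,2-oxazol-4-yl gives a 47-fold higher number from compound 2 to compound 4 (1.67 log units; beyond the scatter), the largest step seen so far at this position, meta to a large group. The new ring also fails to match the unsubstituted phenyl, with a 3.8-fold higher number from compound 1 to compound 4 (0.59 log units; beyond the scatter), so having methyl groups on the outer ring does not by itself bring the gain seen with the 2-methylphenyl group: the kind of ring carrying them matters too. No measurement at hand explains this loss.

The swap changes several things at once: ring size, the presence of nitrogen and oxygen in the ring, and the count of hydrogen-bond acceptors, so the compounds shown cannot say which of these accounts for the step. A methylpyridinyl group, which keeps a six-membered ring but has one ring nitrogen, or a dimethylthiophenyl group, which keeps a five-membered ring but has sulfur in place of the nitrogen and oxygen, would help pull these changes apart.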